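Shortening the Butyl Chain to Methyl

The compounds below may be only part of what the source reports. "The series", "measured", "known", "first", "only" and "open" are said of these compounds alone.

In a functional assay on brain (Rattus norvegicus, strain Wistar) for inhibition (a lower number here means a stronger inhibitor, a higher number a weaker inhibitor), compound 1 `CCCCc1ccc(-c2c(C)[nH]c(=O)n2C)cc1` gives 10700 nM, and compound 2 `CCCCc1ccc(-c2c(C)[nH]c(=O)n2C(C)C)cc1` gives the same figure, 10700 nM. For the measured compounds named here, compound 1 therefore stands level with its only measured neighbour. The next molecule, compound 3 `Cc1ccc(-c2c(C)[nH]c(=O)n2C)cc1`, differs from compound 1 by hydrogen in place of propyl on a saturated chain carbon bound to an aromatic carbon, which turns butyl into methyl. Going by the values given here, the one measured step, no change at the digits printed from compound 1 to compound 2 (within the scatter), swaps isopropyl for methyl on an aromatic nitrogen, a different place, so it offers only weak guidance here. Among the compounds with values here, no measured compound alters the butyl chain, so this forecast is uncertain. So much of the chain goes. Some loss of inhibition seems more likely than a gain. The expected step in this assay, a 2.8-fold higher number from compound 1 to compound 3 (0.45 log units; beyond the scatter), is therefore toward weaker inhibition. For compound 3 the estimated value is 30000 nM, within an expected range of 9000 nM to 100000 nM.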

Compound 3, half-maximal inhibitory concentration: 85300 nM
Beside the measured number, compound 3's estimate is 2.8-fold (0.45 log units) below it, and the stated range covers the measured number.
By their numbers in this assay, from the lowest: compounds 1 and 2 (each within the scatter of the next); then compound 3.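

In this assay, the butyl chain proves to count for inhibition: cutting it back to methyl gives an 8.0-fold higher number from compound 1 to compound 3 (0.90 log units; beyond the scatter), the direction of weaker inhibition. For the compounds shown here, the earlier pair showed only that the group on the aromatic nitrogen could change with no shift in the number, so this is the first change to move the value beyond the scatter. Nothing available explains this loss of inhibition.

The compounds shown leave open how inhibition runs through the chain lengths in between, such as ethyl, and whether a longer chain such as hexyl, or an amine in place of the butyl chain, would give a lower number. As far as these compounds go, it also remains open whether isopropyl on the aromatic nitrogen would still leave the number unchanged alongside the methyl group.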